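Adding 2-fluorophenyl to compound 3

The compounds below may be only part of what the source reports. "The series", "measured", "known", "first", "only" and "open" are said of these compounds alone.

Values in an ADME assay on L6 cells (Rattus norvegicus) for cytotoxicity; a lower number here means a stronger inhibitor, a higher number a weaker inhibitor:
- compound 1 `O=C(NN1Cc2ccccc2C1)c1cc([N+](=O)[O-])ccc1Cl`: 19800 nM
- compound 2 `O=C(NN(c1ccccc1)c1ccccc1)c1cc([N+](=O)[O-])ccc1F`: 3200 nM
- compound 3 `Cn1[nH]c(=O)c2cc([N+](=O)[O-])ccc21`: > 517000 nM

Compound 3 has no exact number, and its reading of > 517000 nM is a limit of the assay. It is the only one of the three measured compounds in that position: the limit of > 517000 nM in this assay, at which 1 of the 3 values shown sits. Compound 4 `O=c1[nH]n(Cc2ccccc2F)c2ccc([N+](=O)[O-])cc12` has not yet been measured in this assay. It differs from compound 3 by one change: 2-fluorophenyl in place of hydrogen on a saturated chain carbon bound to an aromatic nitrogen.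

For the measured compounds named here, no step between measured compounds bears directly on this change, so the expectation rests on a thin comparison. Compound 1 reads 19800 nM and compound 2 reads 3200 nM, and each carries more than one six-membered aromatic ring of carbon, as compound 4 will. A sizeable move towards a lower number, and so towards stronger inhibition, is therefore expected in this assay. The expected size is an at least 5.7-fold lower number from compound 3 to compound 4 (0.75 log units; beyond the scatter). Compound 4 is estimated at 90000 nM, with an expected range from 20000 nM to 400000 nM.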

Compound 4, half-maximal inhibitory concentration: 210000 nM
Compound 4: the middle estimate sits 2.3-fold (0.37 log units) below what was measured; low and high end bracket the measured number.
By their numbers in this assay, from the lowest: compound 2; then compound 1; then compound 4. At a limit, above all of these: compound 3.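

In this assay, 2-fluorophenyl in place of hydrogen on a saturated chain carbon bound to an aromatic nitrogen gives an at least 2.4-fold lower number from compound 3 to compound 4 (0.39 log units; beyond the scatter). The earlier compounds shown here offered no step at this position; this one shows that the number responds to the change there, and compound 4 gives a measured reading of 210000 nM. The size of the step remains a bound and not an exact figure because the reading for compound 3 is a limit of the assay: the limit of > 517000 nM in this assay, at which 1 of the 4 values shown sits.

The compounds shown leave open whether the fluorine contributes to this move or whether a plain phenyl group would read the same. Also open, on these data alone, is how this assay would respond to an amine or a carboxylic acid on the same saturated chain carbon.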